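The compounds below may be only part of what the source reports. "The series", "measured", "known", "first", "only" and "open" are said of these compounds alone.

Working notes on the series. In a functional assay on MCF7 cells (Homo sapiens) for antiproliferative activity, read by MTT assay, with a stated time of 72 h (on this read-out lower numbers stand for stronger inhibition and higher numbers for weaker inhibition), compound 1 (`O=C1COc2ccc(-c3cccc(NS(=O)(=O)c4ccc(F)cc4)c3)cc2N1c1ccc(Cl)cc1`) gives 39800 nM and compound 2 (`COc1ncc(-c2ccc3c(c2)N(C2CC2)C(=O)CO3)cc1NS(=O)(=O)c1ccc(F)cc1`) gives 35200 nM, so the two values lie within the scatter of each other. Compound 3 (`O=C1COc2ccc(-c3cnc4ccccc4c3)cc2N1c1ccc(F)cc1`) returns only a limit, > 40000 nM. Compound 1 therefore has one numerical neighbour, with no separation beyond the scatter, and sits close to the limit of this assay.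

The next compound is compound 4 (`Cc1ccc(N2C(=O)COc3ccc(-c4cccc(NS(=O)(=O)c5ccc(F)cc5)c4)cc32)cc1`), which differs from compound 1 at one place: methyl in place of chloro on an aromatic carbon. This puts methyl in place of chloro on an aromatic carbon, para to a large group, turning 4-chlorophenyl into 4-methylphenyl. For the measured compounds named here, no measured pair isolates a single change, so the swap has no direct precedent here. Starting from compound 1 at 39800 nM, no change beyond the scatter is expected in this assay. The estimated 1.3-fold lower number from compound 1 to compound 4 (0.12 log units; within the scatter) stays within that scatter, and a result reported only as a limit remains possible. For compound 4 the expected value is 30000 nM, with an estimated range of 14000 nM to 40000 nM.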

Compound 4, half-maximal inhibitory concentration: 32100 nM
Estimate against measurement, compound 4: 1.1-fold (0.03 log units) below; measured number inside the range.
By their numbers in this assay, from the lowest: compounds 4, 2 and 1 (each within the scatter of the next). At a limit, above all of these: compound 3.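

In this assay the series now has one step that isolates a single change (a 1.2-fold lower number from compound 1 to compound 4 (0.09 log units; within the scatter)). Methyl in place of chloro on an aromatic carbon, para to a large group, therefore leaves the read-out within the scatter, so turning 4-chlorophenyl into 4-methylphenyl gives no separation at this place. Compound 3 stands at a limit, and any weaker compound at this place could be read only as such a limit, so the room for seeing a loss is narrow: the limit of > 40000 nM in this assay, at which 1 of the 4 values shown sits.

Chloro and methyl are the only pair compared at this place with the rest of the structure unchanged. As far as these compounds go, whether an amine or a carboxylic acid there would move the read-out beyond the scatter remains open, as does whether any group at this place gives a clearly lower number.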